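This account rests on a few compounds, and the source may have more. Where it says the series, first, only, none or still open, it means among the compounds named here.

Compound 1 `Nc1cc(N)c2nc(-c3ccccc3)c(NCc3ccc(Cl)c(Cl)c3)nc2c1`: in a functional assay on SF-268 cells (Homo sapiens) for inhibition, read by sulforhodamine B assay, with a stated time of 48 h (on this read-out lower numbers stand for higher toxicity in this test and higher numbers for lower toxicity in this test), compound 1 gives < 100000 nM, a limit of the assay rather than a number.
Compound 2 `COc1ccc(CNc2nc3cc(N)cc(N)c3nc2-c2ccccc2)cc1OC`: in this assay compound 2 gives < 100000 nM, again a limit and not a number.

Both values rest at the limit of < 100000 nM in this assay, at which 2 of the 2 values shown sit, so the step that the two limits leave unreadable from compound 1 to compound 2 has no readable size. Compound 2 therefore stands only at a limit. Compound 3 `COc1cc(CNc2nc3cc(N)cc(N)c3nc2-c2ccccc2)cc(OC)c1OC` carries methoxy in place of hydrogen on an aromatic carbon. For the measured compounds named here, the single measured step offers no readable size, so no step beyond the scatter can be expected in this assay in either direction. Compound 3 is estimated at 30000 nM, between 5000 nM and 100000 nM. The expected step is a step that the limit leaves unreadable from compound 2 to compound 3.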

Compound 3, concentration lethal to 50% of the cells: 49000 nM
Compound 3: middle estimate off by 1.6-fold (0.21 log units), on the low side; low and high end bracket the measured number.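

No size can be read for the step between compound 2 and compound 3, because compound 2 stands at a limit of the assay, not at a number: the limit of < 100000 nM in this assay, at which 2 of the 3 values shown sit.
The compounds shown leave open whether adding the methoxy group shifts the result in this assay at all.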